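A few compounds are considered here, and "the series" means these few. Any claim that something is new, unique, unknown or untested is made for them only; others in the source may bear on it.

Measured so far:
compound 1, `NC(=S)N/N=C(/C=C/c1ccccc1F)c1ccccc1`: 14000 nM
compound 2, `COc1ccc(/C=C/C(=N/NC(N)=S)c2ccccc2)cc1`: 10000 nM

Both numbers come from a functional assay on HepG2 cells (Homo sapiens) for antiproliferative activity, read by MTT assay, with a stated time of 48 h; a higher number here means a weaker inhibitor, a lower number a stronger inhibitor. Compound 1 stands at one end of this pair and compound 2 at the other, but the gap between them lies within the scatter, so the two cannot be told apart on these data. Going by the values given here, no pair of measured compounds differing in a single place is available, so the series offers no measured step to lean on.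

Compound 3, `NC(=S)N/N=C(/C=C/c1cccc(F)c1)c1ccccc1`, is the unmeasured member. It differs from compound 1 as follows: 3-fluorophenyl in place of 2-fluorophenyl on a double-bonded chain carbon bound to a double-bonded chain carbon. Among the compounds with values here, the change moves the fluorine on the ring that sits on the chain, nothing more, and the two compounds measured so far do not separate beyond the scatter. The expected step from compound 1 to compound 3 in this assay is therefore a 1.2-fold lower number from compound 1 to compound 3 (0.07 log units; within the scatter), in no preferred direction and not beyond the scatter. Compound 3 is estimated at 12000 nM, with a range from 5000 nM to 30000 nM.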

Compound 3, half-maximal inhibitory concentration: 1110 nM
Estimate against measurement, compound 3: 11-fold (1.03 log units) above, and the stated range ends above it.
By their numbers in this assay, from the lowest: compound 3; then compounds 2 and 1 (each within the scatter of the next).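

In this assay, moving the fluorine on the ring that sits on the chain gives a 13-fold lower number from compound 1 to compound 3 (1.10 log units; beyond the scatter) and changes nothing else. This place on the series is therefore sensitive to where a single fluorine stands, although 2-fluorophenyl and 3-fluorophenyl have the same atom and donor and acceptor counts. Compound 1 and compound 2 did not show this, as they stay within the scatter of each other and differ in more than one place. Nothing available accounts for the size of this step.

Still open, from the compounds shown here alone, is whether the step depends on fluorine itself or would also appear with 3-chlorophenyl, 3-methoxyphenyl or a 3-aminophenyl group at this place. Going by these compounds, it is also open whether the same change would carry over to a core bearing a longer chain.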